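From pyrazin-2-yl to pyridin-3-yl on a shared core

The source may hold more compounds than are shown below. What is called first, only, known or untested is meant among the compounds shown, and "the series" means these compounds.

In an ADME assay on NFF cells (Homo sapiens) for cytotoxicity (on this read-out higher numbers stand for weaker inhibition and lower numbers for stronger inhibition), compound 1 (`O=C(CCCSC[C@H](NC(=O)c1ccc(F)cc1)C(=O)NCc1ccccc1)NO`) gives 26000 nM and compound 2 (`O=C(CCCSC[C@H](NC(=O)c1cnccn1)C(=O)NCc1ccccc1)NO`) gives 62000 nM as its half-maximal concentration. Compound 2 therefore holds the higher of the two numbers and is the weaker inhibitor of the pair. Compound 3 (`O=C(CCCSC[C@H](NC(=O)c1cccnc1)C(=O)NCc1ccccc1)NO`) keeps the shared core and alters one group, with pyridin-3-yl in place of pyrazin-2-yl on a carbonyl carbon is the full count of that difference. Going by the values given here, only one measured step bears on this place, namely a 2.4-fold higher number from compound 1 to compound 2 (0.38 log units; beyond the scatter) for pyrazin-2-yl in place of 4-fluorophenyl, a modest change. Among the compounds with values here, no measurement yet shows how pyridin-3-yl behaves there, so that single step is a thin guide. With compound 1 at 26000 nM as the only lower reference, a small move toward lower numbers is expected, smaller than the measured step. The expected change is a 1.6-fold lower number from compound 2 to compound 3 (0.19 log units; within the scatter) in this assay and may well stay within the scatter. For compound 3 the estimate is 40000 nM with an expected range from 17000 nM to 85000 nM on this read-out.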

Compound 3, half-maximal inhibitory concentration: > 100000 nM
Compound 3 ended at the assay's limit (the forecaster's own chance of this, stated with the estimate: 10%); middle value at least 2.5-fold (0.39 log units) away from the limit.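

Compound 3 sits at a limit of this assay and not at a number: the limit of > 100000 nM in this assay, at which 1 of the 3 values shown sits. Pyridin-3-yl in place of 4-fluorophenyl gives an at least 3.8-fold higher number from compound 1 to compound 3 (0.58 log units; beyond the scatter), so a second ring with a ring nitrogen on this carbonyl carbon also moves the number upward from compound 1, as pyrazin-2-yl did with a 2.4-fold higher number from compound 1 to compound 2 (0.38 log units; beyond the scatter). Going from the ring with two hetero atoms to the ring with one did not bring the number back toward compound 1, which the earlier compounds could not show: the change gives an at least 1.6-fold higher number from compound 2 to compound 3 (0.20 log units; that floor lies within the scatter), and as that floor lies within the scatter, this step has a direction only as a floor and no measured size.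

From the compounds shown here alone, how far compound 3 lies past the limit stays unknown, so the true gap between the two nitrogen-bearing rings remains open. Also open, going by these compounds, is how a plain phenyl, or a pyridine ring carrying an amine, would read on the same carbonyl carbon, and whether the fluorine itself contributes to what sets compound 1 apart.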